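The source may hold more compounds than are shown below. What is called first, only, known or untested is meant among the compounds shown, and "the series" means these compounds.

Of the compounds shown here, three built on a shared core have been measured in an in vitro assay on cells for inhibition of Amine oxidase [flavin-containing] B (Homo sapiens), read by coupled enzyme assay, with a stated time of 20 min; a lower number here means a stronger inhibitor, a higher number a weaker inhibitor. Compound 1 `Cn1c(=O)c2c(nc(COc3cccc(Br)c3)n2C)n(C)c1=O` gives 148 nM. Compound 2 `COc1cccc(OCc2nc3c(c(=O)n(C)c(=O)n3C)n2C)c1` gives 1960 nM, and compound 3 `Cn1c(=O)c2c(nc(CCSc3cccc(Cl)c3)n2C)n(C)c1=O` gives 5670 nM. Among these three numbers compound 2 stands second highest: compound 3 lies higher, while compound 1 lies far lower.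

Compound 4 `Cn1c(=O)c2c(nc(COc3cccc(Cl)c3)n2C)n(C)c1=O` is the next compound to be measured. It differs from compound 2 in one place: chloro in place of methoxy on an aromatic carbon. Among the measured compounds shown here, one measured step bears directly on this change: a 13-fold higher number from compound 1 to compound 2 (1.12 log units; beyond the scatter), which put methoxy on the same aromatic carbon where bromo had stood and produced a large rise in the number. Compound 4 reverses that kind of exchange, taking methoxy away and placing chloro on that carbon, so the number is expected to fall by a comparable amount and to land close to compound 1. The step expected here is a 9.8-fold lower number from compound 2 to compound 4 (0.99 log units; beyond the scatter). Compound 4 is therefore estimated at 200 nM, with a likely range from 80 nM to 500 nM.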

Compound 4, half-maximal inhibitory concentration: 334 nM
For compound 4 the middle estimate is 1.7-fold (0.22 log units) below the measured one, within the range that was stated.
By their numbers in this assay, from the lowest: compound 1; then compound 4; then compound 2; then compound 3.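

In this assay, this carbon of the aromatic ring had so far shown only one exchange, and replacing methoxy with chloro now gives a 5.9-fold lower number from compound 2 to compound 4 (0.77 log units; beyond the scatter), so the low number of compound 1 is not unique to bromo. The two halogens still do not match at this position, with a 2.3-fold higher number from compound 1 to compound 4 (0.35 log units; beyond the scatter), and both numbers remain on the lower side of the methoxy compound, compound 2. No measurement offered here accounts for these differences between the three groups.

On these data alone, only bromo, chloro and methoxy appear on this carbon, so it remains open whether fluoro, methyl or a hydroxyl group would give a number closer to the halogens or to methoxy. As far as these compounds go, it is also open whether the same order would hold with these groups on a different carbon of the ring.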